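The compounds below may be only part of what the source reports. "The series", "measured", "known", "first", "only" and "open" are said of these compounds alone.

Four compounds share one core and differ in two places. Compound 1 `C=CCN(CC=C)c1nc(C)nc(Nc2c(C)cc(C)cc2C)n1` carries a 2,4,6-trimethylphenyl group, and in an assay on isolated protein for binding affinity to corticotropin-releasing factor receptor 1 (Homo sapiens) (a higher number here means a weaker inhibitor, a lower number a stronger inhibitor), compound 1 gives 115 nM. Compound 2 `C=CCN(CC=C)c1nc(C)nc(Nc2c(C)cccc2C)n1` carries a 2,6-dimethylphenyl group instead; in this assay compound 2 reaches only a limit of the assay, > 10000 nM. The change methyl in place of hydrogen on an aromatic carbon therefore brings an at least 86-fold lower number from compound 2 to compound 1 (1.93 log units; beyond the scatter), as seen from the limit of > 10000 nM in this assay, at which 2 of the 3 values shown sit. Compound 3 `Cc1nc(NCc2ccc(C(F)(F)F)cc2)nc(Nc2c(C)cccc2C)n1` has another core, and the difference between the two cores is not broken down here. In this assay compound 3 likewise reaches only a limit of the assay, > 10000 nM. Compound 4 `Cc1cc(C)c(Nc2nc(C)nc(NCc3ccc(C(F)(F)F)cc3)n2)c(C)c1` differs from compound 3 by the same change, (methyl in place of hydrogen on an aromatic carbon). Among the measured compounds shown here, because an at least 86-fold lower number from compound 2 to compound 1 (1.93 log units; beyond the scatter) is the single measured instance, on a different core, the expected step is an at least 6.6-fold lower number from compound 3 to compound 4 (0.82 log units; beyond the scatter). For compound 4 the estimate is 1500 nM, between 200 nM and 10000 nM.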

Compound 4, inhibition constant: 1690 nM
Compound 4: middle estimate off by 1.1-fold (0.05 log units), on the low side; low and high end bracket the measured number.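

In this assay, the change from 2,6-dimethylphenyl to 2,4,6-trimethylphenyl again brings an at least 5.9-fold lower number from compound 3 to compound 4 (0.77 log units; beyond the scatter), so on both cores shown the added methyl goes with a stronger inhibitor. This does not show that the size of the step carries over from one core to the other: the same change on two cores in this assay, an at least 86-fold lower number (1.93 log units; beyond the scatter) from compound 2 to compound 1 and an at least 5.9-fold lower number (0.77 log units; beyond the scatter) from compound 3 to compound 4; the limit leaves it open whether they differ. Compound 2 and compound 3, the starting points of the two steps, each sit at a limit of the assay and not at a number: the limit of > 10000 nM in this assay, at which 2 of the 4 values shown sit.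

The compounds shown leave open whether a chlorine or a methoxy group in place of this methyl would give a similar step. They also leave open whether the step would appear on a third core.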